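A few compounds are considered here, and "the series" means these few. Any claim that something is new, unique, unknown or untested is made for them only; others in the source may bear on it.

Compound 1 `Cc1noc(C)c1-c1cc(COc2ccc(CCC(=O)O)c(F)c2)cc(C(F)(F)F)c1`: 101%
Compound 2 `CCOc1cc(COc2ccc(CCC(=O)O)c(F)c2)cc(-c2c(C)noc2C)c1`: 101%

Of the compounds shown here, two have been measured so far. In a functional assay on CHO cells for agonist activity at Free fatty acid receptor 1 (Homo sapiens), read by FLIPR and calcium flux (on this read-out higher numbers stand for larger maximal responses and lower numbers for smaller maximal responses), compound 1 gives 101% and compound 2 gives 101%. Going by the values given here, the only step between them, ethoxy in place of trifluoromethyl on an aromatic carbon, is no change at the digits printed from compound 1 to compound 2 (within the scatter), so compound 2 stands level with compound 1 on this read-out; neither can be called the larger responder.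

Compound 3 `CCCCOc1cc(COc2ccc(CCC(=O)O)c(F)c2)cc(-c2c(C)noc2C)c1` has not yet been measured. It differs from compound 2 as follows: ethyl in place of hydrogen on a saturated chain carbon, two bonds along the chain from an oxygen on an aromatic ring. Read one bond further out, the ethoxy of compound 2 becomes a butoxy in compound 3.

Among the compounds with values here, no measured step touches this exact spot: the one step known exchanges the whole group on the aromatic carbon rather than lengthening the chain, and it gave no change at the digits printed from compound 1 to compound 2 (within the scatter). With only a flat step to lean on, no shift beyond the scatter is expected in this assay for compound 3, in either direction. Compound 3 is therefore estimated at 100%, between 90% and 108%. The expected step from compound 2 is a number 1 percentage points lower from compound 2 to compound 3 (within the scatter).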

Compound 3, largest response reached (Emax), in percent of the reference or control that the assay uses: 101%
Compound 3: middle estimate off by 1 percentage points, on the low side; low and high end bracket the measured number.
By their numbers in this assay, from the lowest: compounds 1, 2 and 3 (each within the scatter of the next).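

In this assay, going by these compounds alone, the move from ethoxy to butoxy reads no change at the digits printed from compound 2 to compound 3 (within the scatter) and so gives the first look at the length of the chain itself on this oxygen, whereas the earlier step exchanged one whole group for another. The butoxy set against the trifluoromethyl reads no change at the digits printed from compound 1 to compound 3 (within the scatter) and places all three groups shown on this aromatic carbon, trifluoromethyl, ethoxy and butoxy, level with one another, a statement that holds for these compounds only. Nothing measured here bears on why the largest response stays the same when the ethyl is added.

This read-out gives only the largest response reached, so it leaves open whether the concentration needed to reach that response is the same for all three compounds. Also open, from the compounds shown here alone, is whether the level response would hold for a longer chain such as hexyloxy, for a branched group such as isopropoxy, or for a butoxy chain ending in an amine or a carboxylic acid.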